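The compounds below may be only part of what the source reports. "The series", "measured", "known", "first", "only" and "open" are said of these compounds alone.

Compound 1 `OC[C@@H]1C[C@H](CO)[C@@H]2C(c3ccc(Cl)cc3)=NO[C@H]12` gives 14.7 ug/mL 
Compound 2 `COc1ccc(C2=NO[C@@H]3[C@H](CO)C[C@H](CO)[C@H]23)cc1OC` gives > 50 ug/mL as a limit, not a number

Going by the values given here, in a functional assay on MCF7 cells (Homo sapiens) for cytotoxicity, read by MTT assay, with a stated time of 48 h (on this read-out lower numbers stand for stronger inhibition and higher numbers for weaker inhibition), compound 1 gives 14.7 ug/mL and holds the only true number so far. Compound 2 stands at > 50 ug/mL and this is a limit of the assay, not a number. Compound 3 `OC[C@@H]1C[C@H](CO)[C@@H]2C(c3ccc(F)cc3)=NO[C@H]12` keeps the core of compound 1, and the change fluoro in place of chloro on an aromatic carbon is fluoro in place of chloro on an aromatic carbon, para to a large group. Among the compounds with values here, no measured pair of compounds shows this swap on its own, so any forecast is uncertain. In this assay the expectation is a modest shift toward weaker inhibition, and none beyond the usual scatter. The expected step is a 1.4-fold higher number from compound 1 to compound 3 (0.13 log units; within the scatter) in this estimate. The estimate for compound 3 is 20 ug/mL with an expected range from 9 ug/mL to 45 ug/mL in repeat measurements.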

Compound 3, half-maximal inhibitory concentration: > 50 ug/mL
Compound 3: only a limit was reported; the forecaster's own chance of this, stated with the estimate: 20%; middle value at least 2.5-fold (0.39 log units) away from the limit.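

In this assay, putting fluoro in place of chloro on an aromatic carbon, para to a large group, gives an at least 3.4-fold higher number from compound 1 to compound 3 (0.53 log units; beyond the scatter), so at this position a change of a single atom is enough to move the result beyond the scatter. Compound 3 gives > 50 ug/mL, which is a limit and not a number. The step is therefore only a lower bound, and of the compounds shown only the chloro compound gives a true number, because the others sit at the limit: the limit of > 50 ug/mL in this assay, at which 2 of the 3 values shown sit.

On these data alone, how far compound 3 lies past the limit stays unknown, so the full size of the step cannot be read. As far as these compounds go, whether bromo, methyl or an amine in this place would match compound 1 at 14.7 ug/mL remains open.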